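Trifluoromethoxy to amino: expected shift in cytotoxicity

The source may report more compounds than this note shows. Statements on the series, on what has been measured and on what is new or still open speak of the compounds shown alone.

Measured in an ADME assay on HepG2 cells (Homo sapiens) for cytotoxicity, with a stated time of 72 h (on this read-out lower numbers stand for an effect already at smaller amounts and higher numbers for an effect only at larger amounts of compound), as follows:
Compound 1 `Cc1cc(NC(=O)Nc2ccccc2N)c2ccccc2n1` gives > 25000 nM (a limit of the assay)
Compound 2 `Cc1cc(NC(=O)Nc2ccc(OC(F)(F)F)cc2)c2ccccc2n1` gives 15000 nM

Going by the values given here, compound 2 holds the only actual number in the set (15000 nM). Its standing can be read only against a limit. Compound 1 sits at that limit (the limit of > 25000 nM in this assay, at which 1 of the 2 values shown sits) and also carries an amino group. Among the compounds with values here, no step between measured compounds is available.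

Compound 3 `Cc1cc(NC(=O)Nc2ccc(N)cc2)c2ccccc2n1` has amino in place of trifluoromethoxy on an aromatic carbon, para to a large group (amino in place of trifluoromethoxy on an aromatic carbon). In this assay a small move toward higher numbers is expected, probably within the scatter, and this rests on compound 1 alone (> 25000 nM). The expected change is a 1.3-fold higher number from compound 2 to compound 3 (0.12 log units; within the scatter) and remains tentative. For compound 3 the estimated value is 20000 nM (range 8000 nM to 40000 nM).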

Compound 3, half-maximal effective concentration: > 25000 nM
Compound 3: only a limit was reported (the forecaster's own chance of this, stated with the estimate: 50%); at least 1.2-fold (0.09 log units) between middle value and limit.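

In this assay, amino in place of trifluoromethoxy on an aromatic carbon, para to a large group, gives an at least 1.6-fold higher number from compound 2 to compound 3 (0.22 log units; that floor lies within the scatter). Compound 3 sits at a limit of the assay, so this change has a floor but no size, and that floor does not establish a real shift. Compound 1 and compound 3, the two compounds shown with an amino group, both end at the top of the read-out: the limit of > 25000 nM in this assay, at which 2 of the 3 values shown sit.

The step from compound 1 to compound 3 cannot be read, so the 2-aminophenyl and 4-aminophenyl forms stay unranked. Open too, going by these compounds, is whether a methoxy group or a carboxylic acid at this position would give an actual number rather than a limit, which would show how far the trifluoromethoxy value can move.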